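The source may report more compounds than this note shows. Statements on the series, on what has been measured and on what is new or still open speak of the compounds shown alone.

Working notes on the series. Among the measured compounds shown here, in a toxicity assay on THP-1 cells (Homo sapiens) for inhibition (on this read-out lower numbers stand for higher toxicity in this test and higher numbers for lower toxicity in this test), compound 1 `Cn1c(-c2ccc(Br)cc2)cnc1NC(=O)c1ccc(F)cc1` gives 46000 nM, the only true number available so far. Compound 2 `COc1ccc(-c2cnc(NC(=O)c3cccnc3)n2C)cc1` reads > 100000 nM, and this is a limit of the assay, not a number. For the measured compounds named here, compound 1 is therefore the sole quantified point, and the series offers no measured step between two close analogues.

The next entry is compound 3 `Cn1c(-c2ccc(C#N)cc2)cnc1NC(=O)c1ccc(F)cc1`, which keeps the core of compound 1 and carries one change, cyano in place of bromo on an aromatic carbon, para to a large group. Going by the values given here, no measured pair shows what this exchange does in this assay, so the expectation is cautious. With compound 1 at 46000 nM as the only anchor, a small shift towards lower toxicity is expected, or none beyond the scatter. The estimated step of a 1.4-fold higher number from compound 1 to compound 3 (0.15 log units; within the scatter) is kept modest for that reason. For compound 3 the estimated value is 65000 nM, with an expected range of 28000 nM to 100000 nM. A reading that reports only the assay limit remains possible.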

Compound 3, half-maximal cytotoxic concentration: > 50000 nM
Compound 3: a limit, no number (the forecaster's own chance of this, stated with the estimate: 35%); the middle value does not contradict the limit.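

Cyano in place of bromo on an aromatic carbon, para to a large group, now has a measured step in this assay: an at least 1.0-fold higher number from compound 1 to compound 3 (0.03 log units; that floor lies within the scatter). That floor gives no sign of a lower number with cyano at this position, but it does not separate compound 3 from compound 1. Compound 3 reads > 50000 nM, a limit of the assay and not a number, so the size of the step stays unknown because the reading ends at that limit: the limit of > 50000 nM in this assay, at which 1 of the 3 values shown sits.

As far as these compounds go, whether the 4-cyanophenyl compound differs from the 4-bromophenyl compound by more than the scatter remains open. Also open, from the compounds shown here alone, is whether an amine or a carboxylic acid para to the large group, on the core of compound 1, would give a true number in this assay or another limit.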